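A few compounds are considered here, and "the series" means these few. Any claim that something is new, unique, unknown or untested is made for them only; others in the source may bear on it.

Measured compounds:
compound 1 `Nc1ncnc2[nH]cc(-c3ccc(NC(=O)c4cn(CC5CCOCC5)cc(-c5ccc(F)cc5)c4=O)cc3)c12` gives 0.2 nM in an assay on isolated protein for inhibition of tyrosine-protein kinase receptor UFO (Homo sapiens), read by ELISA; a higher number here means a weaker inhibitor, a lower number a stronger inhibitor
compound 2 `Cc1nc(N)c2c(-c3ccc(NC(=O)c4cn(CC5CCOCC5)cc(-c5ccc(F)cc5)c4=O)cc3)cn(C)c2n1` gives 5.1 nM in this assay
compound 3 `CN(C)C(=O)Cn1cc(C(=O)Nc2ccc(-c3cn(C)c4ncnc(N)c34)cc2)c(=O)c(-c2ccc(F)cc2)c1` gives 0.5 nM in this assay

Compound 1 holds the lowest number of the three. Compound 3 sits nearest to it, and compound 2 sits furthest, with a 26-fold higher number from compound 1 to compound 2 (1.41 log units; beyond the scatter), a large step that came from exchanging one bicyclic core for another. Compound 3 differs from compound 1 in more than one place, so its value is only read as a whole: it carries a methyl group on an aromatic nitrogen of the core and a different chain on the amide side, and it keeps a number close to that of compound 1.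

Compound 4 `CN(C)CCn1cc(-c2ccc(NC(=O)c3cn(CC4CCOCC4)cc(-c4ccc(F)cc4)c3=O)cc2)c2c(N)ncnc21` differs from compound 1 by 2-(dimethylamino)ethyl in place of hydrogen on an aromatic nitrogen. Going by the values given here, no measured step matches this change exactly. Among the compounds with values here, the only counted step, from compound 1 to compound 2, alters the core itself and is therefore a poor guide. The value of compound 3 shows that a small group on an aromatic nitrogen of the core still leaves a low number. Compound 4 is therefore expected to stay near compound 1, with at most a modest rise, an expected step of a 3.0-fold higher number from compound 1 to compound 4 (0.48 log units; beyond the scatter). The estimated value of compound 4 is 0.6 nM, within a range from 0.15 nM to 3 nM.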

Compound 4, half-maximal inhibitory concentration: 2.8 nM
Compound 4: middle estimate off by 4.7-fold (0.67 log units), on the low side; measured number inside the range.
By their numbers in this assay, from the lowest: compound 1; then compound 3; then compounds 4 and 2 (each within the scatter of the next).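

In this assay the aromatic nitrogen of the five-membered ring in the core of compound 1 proves sensitive to substitution: 2-(dimethylamino)ethyl in place of hydrogen there gives a 14-fold higher number from compound 1 to compound 4 (1.15 log units; beyond the scatter) and counts as a large step. Going by these compounds alone, this is the first reading of a change at this position taken on its own, for the only earlier step altered the core itself and compound 3 differs from compound 1 in more than one place. Nothing shown accounts for the size of this step.

As far as these compounds go, whether the step follows from the chain as a whole or from its amine stays open, and an ethyl group or a 2-hydroxyethyl chain on the same aromatic nitrogen, with the rest of compound 1 kept, would separate the two. Also open, from the compounds shown here alone, is what a methyl group alone does on compound 1, as compound 3 carries one only together with a different chain on the amide side.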